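Aryloxymethyl oxazoline series: nitro for methoxy

The source may report more compounds than this note shows. Statements on the series, on what has been measured and on what is new or still open speak of the compounds shown alone.

Compound 1 `COc1ccc(OCC2=NCCO2)cc1` in a toxicity assay on the whole organism with Rattus norvegicus as the target, at a dose of 100 mg/kg by the oral route (a lower number here means a weaker effect, a higher number a stronger effect of the compound at the dose given), gives 5%. Compound 2 `Cc1cccc(OCC2=NCCO2)c1` gives 15% in this assay, which lies within the scatter of compound 1. Compound 3 `O=[N+]([O-])c1ccccc1OCC1=NCCO1` gives 20% in this assay, beyond the scatter of compound 1, so compound 1 stands at the low end of the three numbers, separated clearly only from compound 3. Compound 4 `O=[N+]([O-])c1ccc(OCC2=NCCO2)cc1` has not been measured; it differs from compound 1 by nitro in place of methoxy on an aromatic carbon. Going by the values given here, no pair of measured compounds differing in one place is available, so the size of this change cannot be read from a comparable step. Compound 3 also carries a nitro group and gives 20% in this assay. For compound 4 a value of 18% is expected, ranging from 5% to 35%. The expected step of a number 13 percentage points higher from compound 1 to compound 4 (beyond the scatter) is upward but modest, possibly not beyond the scatter.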

Compound 4, a percentage reported as activity, at one dose (the size of the read-out at that dose, not a potency): 10%
Compound 4: the middle estimate sits 8 percentage points above what was measured, and the stated range covers the measured number.
By their numbers in this assay, from the lowest: compounds 1, 4, 2 and 3 (each within the scatter of the next, the first and the last beyond it).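

In this assay, going by these compounds alone, nitro in place of methoxy on an aromatic carbon, para to a group of 7 heavy atoms, gives a number 5 percentage points higher from compound 1 to compound 4 (within the scatter) as the first single-place step. At this position, the exchange therefore does not separate the two compounds, even though it replaces one hydrogen-bond acceptor with two. No measured property bears on this result. Going by these compounds, whether an amine or a carboxylic acid at this position would give a step beyond the scatter remains open, as does the outcome of the same exchange elsewhere on the ring.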